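The source may report more compounds than this note shows. Statements on the series, on what has been measured and on what is new or still open speak of the compounds shown alone.

In an ADME assay on L6 cells (Rattus norvegicus) for cytotoxicity, read by resazurin assay, with a stated time of 72 h (on this read-out higher numbers stand for weaker inhibition and lower numbers for stronger inhibition), compound 3 `CS(=O)(=O)c1ccc(C(=O)NC(=O)c2ccccc2O)cc1` gives > 100 ug/mL, which is a limit of the assay and not a number. Two relatives on the shared core do give numbers: compound 1 `Cc1ccc(C(=O)NC(=O)c2ccccc2O)cc1` reads 46 ug/mL, and compound 2 `CC(C)(C)c1ccc(C(=O)NC(=O)c2ccccc2O)cc1` reads 2.3 ug/mL. Compound 4 `CCCCOc1ccc(C(=O)NC(=O)c2ccccc2O)cc1` has yet to be measured. It differs from compound 3 by butoxy in place of methylsulfonyl on an aromatic carbon, para to a large group: butoxy in place of methylsulfonyl on an aromatic carbon.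

Three measured steps at this same place bear on the change. Exchanging methyl for tert-butyl gave a 20-fold lower number from compound 1 to compound 2 (1.30 log units; beyond the scatter). Moving to methylsulfonyl gave an at least 2.1-fold higher number from compound 1 to compound 3 (0.33 log units; beyond the scatter) from the methyl side, and an at least 43-fold higher number from compound 2 to compound 3 (1.63 log units; beyond the scatter) from the tert-butyl side. Butoxy is judged closer to the tert-butyl of compound 2 than to the methylsulfonyl of compound 3, so a large step to a lower number is expected, running against an at least 43-fold higher number from compound 2 to compound 3 (1.63 log units; beyond the scatter). The expected change is an at least 16-fold lower number from compound 3 to compound 4 (1.22 log units; beyond the scatter). For compound 4 the estimated value is 6 ug/mL, with an expected range from 1.5 ug/mL to 30 ug/mL.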

Compound 4, half-maximal inhibitory concentration: 13 ug/mL
Beside the measured number, compound 4's estimate is 2.2-fold (0.34 log units) below it, within the range that was stated.
By their numbers in this assay, from the lowest: compound 2; then compound 4; then compound 1. At a limit, above all of these: compound 3.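

In this assay, the low number at this position proves not to belong to tert-butyl alone: butoxy also lowers it, with a 3.5-fold lower number from compound 1 to compound 4 (0.55 log units; beyond the scatter), though not as far as tert-butyl, with a 5.7-fold higher number from compound 2 to compound 4 (0.75 log units; beyond the scatter). Replacing methylsulfonyl with butoxy gives an at least 7.6-fold lower number from compound 3 to compound 4 (0.88 log units; beyond the scatter), so the group that enters moves the reading back from the top of the assay's range into the span of the numbered compounds. Compound 3 stands at a limit and not at a number, so this step is only a bound: the limit of > 100 ug/mL in this assay, at which 1 of the 4 values shown sits.

Four groups at one place cannot show whether the oxygen of butoxy or its chain matters more to the reading. From the compounds shown here alone, how a plain butyl chain, a shorter methoxy or an amine at this place would compare with compound 4 remains open.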